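Hydroxy to hydrogen on the chain of compound 1

The source may report more compounds than this note shows. Statements on the series, on what has been measured and on what is new or still open speak of the compounds shown alone.

Measured so far:
compound 1, `C=CCn1c(=O)n(CCCCO)c2nc(N)nc(O)c21`, 12%
compound 2, `C=CCn1c(=S)n(COCCO)c2nc(N)nc(O)c21`, 9%

Both numbers come from a functional assay on the whole organism (B cells) with Mus musculus as the target; a higher number here means a larger maximal response, a lower number a smaller maximal response. In this assay compound 1 gives 12% and compound 2 gives 9%; the two lie within the usual scatter of each other, so nothing separates them. Compound 2 differs from compound 1 in more than one place, so no single step between them is shown.

Compound 3, `C=CCn1c(=O)n(CCCC)c2nc(N)nc(O)c21`, differs from compound 1 in one place: hydrogen in place of hydroxy on a saturated chain carbon, four bonds along the chain from an aromatic nitrogen. Among the compounds with values here, no step between measured compounds matches this change, so its size is not known from the series. With compound 1 at 12% and compound 2 at 9%, both low, a small maximal response is all that has been seen so far. The step of no change at the digits printed from compound 1 to compound 3 (within the scatter) is expected to be none beyond the scatter. Compound 3 is estimated at 12%, within 3% to 25%.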

Compound 3, largest response reached (reported as maximal response), in percent of the reference or control that the assay uses: 77%
Estimate against measurement, compound 3: 65 percentage points below, outside the stated range (above it).
By their numbers in this assay, from the lowest: compounds 2 and 1 (each within the scatter of the next); then compound 3.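

Hydrogen in place of hydroxy on a saturated chain carbon, four bonds along the chain from an aromatic nitrogen, gives in this assay a number 65 percentage points higher from compound 1 to compound 3 (beyond the scatter) and marks this chain end as a sensitive position. Until now only small maximal responses had been seen, and compound 3 shows that the shared core can carry a large one once the hydroxy is gone. Nothing at hand gives a reason for the size of this step.

Open, on these data alone, is whether an amine or a carboxylic acid on the same chain carbon would keep the response as low as the hydroxy of compound 1 does, and whether a longer chain would hold the level of compound 3. As far as these compounds go, the separate effect of the thiocarbonyl in compound 2 also stays open, with compound 2 differing from compound 1 in more than one place.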